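Swapping chloro for trifluoromethoxy in a nitrofuran amide series

A few compounds are considered here, and "the series" means these few. Any claim that something is new, unique, unknown or untested is made for them only; others in the source may bear on it.

Measured in an ADME assay on Vero cells (Chlorocebus sabaeus) for cytotoxicity, read by MTT assay, with a stated time of 48 h; a higher number here means that more compound is tolerated, a lower number that less compound is tolerated:
- compound 1, `CC(C)C(NC(=O)c1ccc([N+](=O)[O-])o1)c1ccccc1`, gives 22000 nM
- compound 2, `O=C(NC(=O)c1ccc([N+](=O)[O-])o1)c1ccccc1`, gives 3000 nM
- compound 3, `CC(C)(NC(=O)c1ccc([N+](=O)[O-])o1)c1ccc(Cl)cc1`, gives 81000 nM

Among these three numbers compound 3 stands highest, so the cells tolerate more of it than of the others. Its nearest neighbour is compound 1, and even that gap lies beyond the usual scatter of repeated measurements; the gap to compound 2, the furthest, is wider still.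

Compound 4, `CC(C)(NC(=O)c1ccc([N+](=O)[O-])o1)c1ccc(OC(F)(F)F)cc1`, has not yet been tested. It differs from compound 3 in a single place: trifluoromethoxy in place of chloro on an aromatic carbon. For the measured compounds named here, no two of the measured compounds differ from each other by just one such change, so there is no measured step of this kind to lean on; the three measured compounds differ from one another in several places at once.

With that in mind, the step from compound 3 to compound 4 in this assay is expected to stay within the scatter, in either direction, as a 1.4-fold lower number from compound 3 to compound 4 (0.13 log units; within the scatter). For compound 4 the expected value is 60000 nM, with a likely range from 25000 nM to 150000 nM.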

Compound 4, half-maximal cytotoxic concentration: 70000 nM
The estimate for compound 4 lay 1.2-fold (0.07 log units) below the measured number, and the stated range covers the measured number.
By their numbers in this assay, from the lowest: compound 2; then compound 1; then compounds 4 and 3 (each within the scatter of the next).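

For the compounds shown here, until now, no two measured compounds differed in just one place, so this pair gives the first direct reading of a single change. In this assay, putting trifluoromethoxy in place of chloro on an aromatic carbon, para to a large group, gives a 1.2-fold lower number from compound 3 to compound 4 (0.06 log units; within the scatter) and so cannot be told apart from repeat-to-repeat variation. At this place on the core of compound 3, then, a group of 5 heavy atoms that brings a hydrogen-bond acceptor can stand where a single chlorine stood, with no detectable difference in how much compound the cells tolerate. Nothing available here bears on why these two groups give matching numbers.

This single pair cannot show whether the tolerance would also hold for quite different groups at this place, such as an amine, a carboxylic acid or a longer alkyl chain. Nor does it show whether trifluoromethoxy and chloro would also match on the core of compound 1, which carries an isopropyl group and an unsubstituted aromatic ring.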